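Swapping the amide substituent in a weakly cytotoxic series

The compounds below may be only part of what the source reports. "The series", "measured", "known", "first", "only" and "open" are said of these compounds alone.

Three compounds share one core and differ at the amide nitrogen and on the aryl ring. Compound 1 `C=CC1=C(C(=O)Nc2ccc(OCC)cc2)C(c2ccc(OC)cc2)OC1` gives in a functional assay on QGY7701 cells (Homo sapiens) for cytotoxicity, read by MTT assay, with a stated time of 24 h (on this read-out higher numbers stand for weaker inhibition and lower numbers for stronger inhibition), only a limit, > 100000 nM, so its value is known as a boundary rather than a number. Compound 3 `C=CC1=C(C(=O)Nc2ccc(OCC)cc2)C(c2ccc(F)cc2)OC1` gives 61600 nM in this assay, and compound 2 `C=CC1=C(C(=O)NCc2ccccc2)C(c2ccc(F)cc2)OC1` gives 67600 nM in this assay. The step of an at least 1.6-fold lower number from compound 1 to compound 3 (0.21 log units; that floor lies within the scatter) runs against a limit, so its true size is open; what is known of compound 1 rests on (the limit of > 100000 nM in this assay, at which 1 of the 3 values shown sits). Compound 4 `C=CC1=C(C(=O)NCc2ccccc2F)C(c2ccc(OC)cc2)OC1` is not yet measured; it differs from compound 1 as follows: 2-fluorobenzyl in place of 4-ethoxyphenyl on an amide-type nitrogen. Within the data shown here, no measured step changes exactly this group. The nearest comparison is the pair compound 2 and compound 3, which carry a benzyl and a 4-ethoxyphenyl on the amide nitrogen and sit close to one another in this assay, so that pair gives no sign that the amide substituent moves the read-out. Compound 4 is therefore expected to stay near compound 1, with an at least 1.1-fold lower number from compound 1 to compound 4 (0.04 log units; that floor lies within the scatter) expected to lie within the scatter. The estimate for compound 4 is 90000 nM, between 40000 nM and 200000 nM.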

Compound 4, half-maximal inhibitory concentration: > 100000 nM
Compound 4 gave a limit, no number (the forecaster's own chance of this, stated with the estimate: 45%); at least 1.1-fold (0.04 log units) between middle value and limit.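

Compound 1 and compound 4 both stand only as limits in this assay, so the step between them cannot be read. What is known of the two rests on a single boundary: the limit of > 100000 nM in this assay, at which 2 of the 4 values shown sit.

The compounds shown leave open whether 2-fluorobenzyl in place of 4-ethoxyphenyl on the amide-type nitrogen changes the read-out at all.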